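A few compounds are considered here, and "the series" means these few. Any claim that something is new, unique, unknown or untested is made for them only; others in the source may bear on it.

Working notes on the series: in a functional assay on MCF7 cells (Homo sapiens) for inhibition, read by sulforhodamine B assay, with a stated time of 48 h, tested at 50 uM (a lower number here means less inhibition of growth, a higher number more inhibition of growth at the concentration tested), compound 1 `COc1cc2c(cc1CCC(C)C)C(=O)C[C@@H](c1ccc(O)cc1)O2` gives 81% and compound 2 `COc1ccc([C@@H]2C/C(=N/OCc3cn(-c4ccc(Cl)cc4C)nn3)c3cc(CC=C(C)C)c(OC)cc3O2)cc1` gives 37%. Compound 2 therefore holds the lower of the two numbers, with the gap beyond the scatter. Compound 3 `COc1ccc([C@@H]2C/C(=N/OCc3cn(-c4ccc(NC(C)=O)cc4)nn3)c3cc(CC=C(C)C)c(OC)cc3O2)cc1` is still unmeasured and carries 4-acetamidophenyl in place of 4-chloro-2-methylphenyl on an aromatic nitrogen. Among the compounds with values here, no measured pair isolates this change, so the expectation is loose. In this assay, no change beyond the scatter is expected, with an estimated step of a number 3 percentage points higher from compound 2 to compound 3 (within the scatter). For compound 3 the estimated value is 40%, with an expected range of 20% to 60%.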

Compound 3, percent growth inhibition at one concentration: 0%
For compound 3 the middle estimate is 40 percentage points above the measured one, and the stated range ends above it.
By their numbers in this assay, from the lowest: compound 3; then compound 2; then compound 1.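

In this assay the aryl group on the aromatic nitrogen of the five-membered aromatic ring with 3 nitrogen clearly matters: 4-acetamidophenyl in place of 4-chloro-2-methylphenyl gives a number 37 percentage points lower from compound 2 to compound 3 (beyond the scatter), and compound 3 stands at 0% at the concentration tested. The inhibition seen with compound 2 therefore does not come from the shared core alone. Nothing available accounts for this loss. The compounds shown do not separate losing the chloro and methyl groups from gaining the acetamido group. From the compounds shown here alone, whether unsubstituted phenyl or 4-aminophenyl at this position restores any inhibition remains open.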